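A few compounds are considered here, and "the series" means these few. Any claim that something is new, unique, unknown or untested is made for them only; others in the source may bear on it.

Compound 1 `CCC(C)OC(=O)C1=C(C)NC(=O)NC1c1ccco1` gives 3% in an assay on membranes from HeLa cells for displacement of a labelled ligand from adenosine receptor A3 (Homo sapiens), read by scintillation counting, with a stated time of 180 min, tested at 1 uM; a lower number here means less inhibition, a higher number more inhibition at the concentration tested (going by the name of the read-out). Compound 2 `CC1=C(C(=O)OC2CCC2)C(c2ccco2)NC(=O)N1` carries one change relative to it, (cyclobutyl in place of sec-butyl on an oxygen next to a carbonyl group), and compound 2 gives 1%; that change made a number 2 percentage points lower from compound 1 to compound 2 (within the scatter). Compound 3 `CCC(C)OC(=O)C1=C(C)NC(=O)NC1c1ccsc1` differs from compound 1 in the core instead: thiophen-3-yl in place of furan-2-yl on a saturated ring carbon. In this assay compound 3 gives 7%, a step of a number 4 percentage points higher from compound 1 to compound 3 (within the scatter). Compound 4 `CC1=C(C(=O)OC2CCC2)C(c2ccsc2)NC(=O)N1`, not yet measured, combines both differences: it differs from compound 3 by cyclobutyl in place of sec-butyl on an oxygen next to a carbonyl group, the same change already seen between compound 1 and compound 2, now made on the core of compound 3. Since that change on the core of compound 1 gave a number 2 percentage points lower from compound 1 to compound 2 (within the scatter), the step from compound 3 to compound 4 is expected to be similarly small, a number 2 percentage points lower from compound 3 to compound 4 (within the scatter). Compound 4 is therefore estimated to give about 5%, somewhere between -2% and 12%.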

Compound 4, a percentage reported as inhibition, at one concentration (the size of the read-out at that concentration, not a potency): 3%
The estimate for compound 4 lay 2 percentage points above the measured number; low and high end bracket the measured number.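

In this assay, cyclobutyl in place of sec-butyl gives a number 4 percentage points lower from compound 3 to compound 4 (within the scatter), and set beside the same change on the other core it looks alike: the same change on two cores in this assay, a number 2 percentage points lower (within the scatter) from compound 1 to compound 2 and a number 4 percentage points lower (within the scatter) from compound 3 to compound 4, 2 percentage points apart, within the scatter of two such steps. Thiophen-3-yl in place of furan-2-yl gives a number 2 percentage points higher from compound 2 to compound 4 (within the scatter), and this change also looks alike on both cores: the same change on two cores in this assay, a number 4 percentage points higher (within the scatter) from compound 1 to compound 3 and a number 2 percentage points higher (within the scatter) from compound 2 to compound 4, 2 percentage points apart, within the scatter of two such steps. Among the compounds shown here, neither change moves the read-out beyond the scatter on either core, but that does not show that a change with a clear effect would carry over from one core to another, and no step here is large enough to test this.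

The compounds shown leave open whether a longer chain or a benzyl group in place of sec-butyl would give clear inhibition at this concentration. The same question stands for a phenyl ring carrying an amine or a carboxylic acid in place of furan-2-yl.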